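Working notes: ethylsulfonyl to (3,5-dimethylpiperazin-1-yl)carbonyl

This account rests on a few compounds, and the source may have more. Where it says the series, first, only, none or still open, it means among the compounds named here.

Measured so far in a functional assay on CWR22R cells (Homo sapiens) for antiproliferative activity, read by MTT assay, with a stated time of 3 days (a lower number here means a stronger inhibitor, a higher number a weaker inhibitor), for three compounds:
- compound 1 `CCS(=O)(=O)Nc1ccc(-c2cc(=O)c3c(O)cc(OC)c(OC(C)C)c3o2)cc1` gives 2900 nM
- compound 2 `COc1cc(O)c2c(=O)cc(-c3ccc(NS(=O)(=O)C4CC4)cc3)oc2c1OC(C)C` gives 19700 nM
- compound 3 `COc1cc(O)c2c(=O)cc(-c3ccc(NC(=O)N4CCCNCC4)cc3)oc2c1OC(C)C` gives 6100 nM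

Compound 1 holds the lowest of the three numbers, and its steps to both others lie beyond the scatter. The next compound to be measured is compound 4 `COc1cc(O)c2c(=O)cc(-c3ccc(NC(=O)N4CC(C)NC(C)C4)cc3)oc2c1OC(C)C` and it differs from compound 1 as follows: (3,5-dimethylpiperazin-1-yl)carbonyl in place of ethylsulfonyl on a nitrogen on an aromatic ring with (3,5-dimethylpiperazin-1-yl)carbonyl in place of ethylsulfonyl on a nitrogen on an aromatic ring.

For the measured compounds named here, the closest precedent is compound 3, which carries (1,4-diazepan-1-yl)carbonyl on that nitrogen and shows a 2.1-fold higher number from compound 1 to compound 3 (0.32 log units; beyond the scatter) as a modest step. Changing only the sulfonyl group gave a larger modest step (a 6.8-fold higher number from compound 1 to compound 2 (0.83 log units; beyond the scatter)), and compound 3 lies on the lower side of compound 2 (a 3.2-fold lower number from compound 2 to compound 3 (0.51 log units; beyond the scatter)). Going by the values given here, no measured compound carries the (3,5-dimethylpiperazin-1-yl)carbonyl group, so this rests on one close comparison. Compound 3 at 6100 nM therefore serves as the anchor, and a modest step to a higher number is expected in this assay for the new compound. The step expected is a 1.9-fold higher number from compound 1 to compound 4 (0.28 log units; within the scatter) as a working estimate. For compound 4 the estimated value is 5500 nM in this assay (expected range 2200 nM to 14000 nM).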

Compound 4, half-maximal inhibitory concentration: 800 nM
Compound 4: the middle estimate sits 6.9-fold (0.84 log units) above what was measured; measured number below the stated range.
By their numbers in this assay, from the lowest: compound 4; then compound 1; then compound 3; then compound 2.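

Notes on the nitrogen on an aromatic ring, in this assay: a carbonyl-linked ring in place of ethylsulfonyl can lower the number as well as raise it, since the (3,5-dimethylpiperazin-1-yl)carbonyl group gives a 3.6-fold lower number from compound 1 to compound 4 (0.56 log units; beyond the scatter), whereas the (1,4-diazepan-1-yl)carbonyl group gave a 2.1-fold higher number from compound 1 to compound 3 (0.32 log units; beyond the scatter). For the compounds shown here, the ring on the carbonyl carbon therefore matters at this position: 3,5-dimethylpiperazin-1-yl in place of 1,4-diazepan-1-yl gives a 7.6-fold lower number from compound 3 to compound 4 (0.88 log units; beyond the scatter), and the same group in place of cyclopropylsulfonyl gives the only large step in the set, a 25-fold lower number from compound 2 to compound 4 (1.39 log units; beyond the scatter). Nothing available explains these differences.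

The compounds shown do not separate the contribution of the six-membered ring from that of its two methyl groups, a question that a plain piperazin-1-yl carbonyl group would address directly. Also open, going by these compounds, is how far this position tolerates further substitution of the 3,5-dimethylpiperazin-1-yl group, for example a methyl or a longer alkyl chain on its free ring nitrogen.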